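The source may report more compounds than this note shows. Statements on the series, on what has been measured and on what is new or still open speak of the compounds shown alone.

Measured compounds in a functional assay on HeLa cells (Homo sapiens) for inhibition, read by MTT assay, with a stated time of 24 h; on this read-out lower numbers stand for stronger inhibition and higher numbers for weaker inhibition: compound 1 `CCOC(=O)C1=Cc2ccccc2OC1(OCc1cn(CC(=O)Nc2ccc(C)cc2)nn1)C(F)(F)F` gives 67400 nM. Compound 2 `O=C(O)C1=Cc2ccccc2OC1(OCc1cc(-c2ccc([N+](=O)[O-])cc2)no1)C(F)(F)F` gives > 150000 nM, which is a limit of the assay and not a number. Compound 3 `CCOC(=O)C1=Cc2ccccc2OC1(OCc1cc(-c2ccc([N+](=O)[O-])cc2)no1)C(F)(F)F` gives > 150000 nM, likewise a limit.

Compound 2 therefore stands at the upper edge of what this assay can report; as the limit of > 150000 nM in this assay, at which 2 of the 3 values shown sit, shows, it shares that position with compound 3, and only compound 1 returned a number. Among the compounds with values here, the single measured step, a step that the two limits leave unreadable from compound 2 to compound 3, changes the acid end of the molecule and cannot be read, since both of its ends are limits.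

Compound 4 `O=C(O)C1=Cc2ccccc2OC1(OCc1cc(-c2ccc(F)cc2)no1)C(F)(F)F` differs from compound 2 by fluoro in place of nitro on an aromatic carbon. Within the data shown here, no measured step touches this position, so nothing here tells how large a change to expect, in either direction, beyond the scatter. Given that compound 2 already sits at the limit, compound 4 is expected to remain there or close to it, with an estimated 150000 nM, ranging from 50000 nM to 400000 nM. The expected step of a number no higher from compound 2 to compound 4 (the limit leaves the size open) is accordingly small and uncertain.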

Compound 4, half-maximal inhibitory concentration: > 150000 nM
Compound 4: a limit, no number (the forecaster's own chance of this, stated with the estimate: 65%); the middle value sits exactly at the limit.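

Within the data shown here, compound 4 gives > 150000 nM as a limit of the assay and not a number, so no step between compound 2 and compound 4 can be read. The compounds shown leave open how far 4-nitrophenyl and 4-fluorophenyl differ in this assay at all.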